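The source may hold more compounds than are shown below. What is called first, only, known or untested is meant among the compounds shown, and "the series" means these compounds.

Compound 3 `Fc1ccc(-c2csc(N/N=C\c3cccs3)n2)cc1` gives 40% in an in vitro assay on BTI-TN-5B1-4 cells for inhibition of Amine oxidase [flavin-containing] A (Homo sapiens), read by Amplex Red, with a stated time of 15 min, tested at 100 uM; on this read-out higher numbers stand for more inhibition at the one concentration tested (going by the name of the read-out) and lower numbers for less inhibition. Its nearest neighbour on the numbers is compound 2 `Fc1ccc(-c2csc(N/N=C\c3ccco3)n2)cc1`, which gives 40% in this assay; the step of no change at the digits printed from compound 2 to compound 3 (within the scatter) lies within the scatter, so the two compounds stand level. A further entry, compound 1 `O=[N+]([O-])c1ccc(-c2csc(N/N=C\c3ccncc3)n2)cc1`, carries the same pyridin-4-yl group that compound 4 receives, but on a different core, and in this assay compound 1 is reported as "not active" (no number reported) without a number.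

Compound 4 `Fc1ccc(-c2csc(N/N=C\c3ccncc3)n2)cc1` differs from compound 3 in one place: pyridin-4-yl in place of thiophen-2-yl on a carbon with a double bond to nitrogen

Going by the values given here, only one measured step bears on this change, and only loosely: the step of no change at the digits printed from compound 2 to compound 3 (within the scatter) shows that exchanging one five-membered aromatic ring for another on the carbon double-bonded to nitrogen left the read-out unchanged. Among the compounds with values here, no measured pair exchanges a five-membered ring for a six-membered pyridin-4-yl on the fluoro-bearing core. Within the data shown here, the report on compound 1 hints that pyridin-4-yl may sit lower, but its core is different, so no step can be drawn from it.

Compound 4 is therefore expected to show a modest loss, with the step of a number 15 percentage points lower from compound 3 to compound 4 (beyond the scatter) taken as the estimate. In this assay compound 4 is estimated at 25%, within a range from 0% to 50%.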

Compound 4, a percentage reported as inhibition, at one concentration (the size of the read-out at that concentration, not a potency): 40%
For compound 4 the middle estimate is 15 percentage points below the measured one; measured number inside the range.
By their numbers in this assay, from the lowest: compounds 2, 3 and 4 (each within the scatter of the next).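

In this assay, the step of no change at the digits printed from compound 3 to compound 4 (within the scatter) shows that, on the shared core, the carbon with a double bond to nitrogen can carry a six-membered aromatic ring as well as a five-membered one without a change in the read-out beyond the scatter. The step of no change at the digits printed from compound 2 to compound 4 (within the scatter) agrees with this, so furan-2-yl, thiophen-2-yl and pyridin-4-yl cannot be told apart at this position by this read-out. Pyridin-4-yl on the shared core thus gives a number, whereas compound 1, which carries the same group on its own core, is reported as "not active" (no number reported).

No measurement shown here offers an explanation for why these three groups stand level. From the compounds shown here alone, it remains open whether a group of a different kind at this position, such as an amine or a carboxylic acid, would also stand level with them, and whether compounds that stand level at this one concentration would also match in potency.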